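The compounds below may be only part of what the source reports. "The series", "measured", "known", "first", "only" and "open" are said of these compounds alone.

Working notes on the series.

Compound 1 `COC(=O)[C@@]1(C)CCC=C2[C@@H]1CC[C@@H](C)[C@]2(C)Cc1c[nH]c2c(Br)cccc12` and compound 2 `COC(=O)[C@@]1(C)CCC=C2[C@@H]1CC[C@@H](C)[C@]2(C)Cc1c[nH]c2c(Cl)cccc12` share one core and differ in a single place: chloro in place of bromo on an aromatic carbon. In a functional assay on HBL-100 cells (Homo sapiens) for inhibition, read by sulforhodamine B assay, with a stated time of 48 h (on this read-out lower numbers stand for stronger inhibition of growth and higher numbers for weaker inhibition of growth), compound 1 gives 18000 nM, and in this assay compound 2 gives 19000 nM. That exchange produced a 1.1-fold higher number from compound 1 to compound 2 (0.02 log units; within the scatter), so on this pair the halogen swap left the read-out essentially where it was.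

Compound 3 `COC(=O)[C@@]1(C)CCC=C2[C@@H]1CC[C@@H](C)[C@]2(C)Cc1c(C)[nH]c2ccc(Br)cc12` sits on a different core; how the core of compound 3 differs from the core of compound 1 is not broken down here. In this assay compound 3 gives 15000 nM. Its gaps to compound 1 and to compound 2 are both within the scatter, so no order among the three measured compounds is claimed.

Compound 4 `COC(=O)[C@@]1(C)CCC=C2[C@@H]1CC[C@@H](C)[C@]2(C)Cc1c(C)[nH]c2ccc(Cl)cc12` is the not yet measured partner of compound 3, and differs from it in one place: chloro in place of bromo on an aromatic carbon. Within the data shown here, this is the same kind of change as the one from compound 1 to compound 2, not the same change, since the surroundings differ: in compound 1 the halogen is ortho to a fused ring and meta to a fused ring, whereas in compound 3 it is meta to a fused ring and para to a fused ring.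

For compound 4 the step from compound 3 is expected to be a 1.1-fold higher number from compound 3 to compound 4 (0.03 log units; within the scatter), an expectation that rests on a 1.1-fold higher number from compound 1 to compound 2 (0.02 log units; within the scatter) having stayed within the scatter. Compound 4 is therefore estimated at 16000 nM in this assay, with an expected range from 8000 nM to 32000 nM.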

Compound 4, concentration for 50% growth inhibition: 15000 nM
The estimate for compound 4 lay 1.1-fold (0.03 log units) above the measured number; the range from low to high includes it.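

In this assay, chloro in place of bromo gives no change at the digits printed from compound 3 to compound 4 (within the scatter), so on the core of compound 3 the halogen swap again leaves the read-out where it was. Set beside the earlier pair, the same change on the second core shows no difference beyond the scatter: the same change on two cores in this assay, a 1.1-fold higher number (0.02 log units; within the scatter) from compound 1 to compound 2 and no change at the digits printed (within the scatter) from compound 3 to compound 4, 1.1-fold (0.02 log units) apart, within the scatter of two such steps. Within these two pairs, the exchange can therefore be carried from one core to the other without a detectable shift in this read-out, but this does not show that it would stay silent on a further core, at another place on the ring, or in a compound with a much lower number, and the two pairs cannot separate the effect of the core from that of the halogen's surroundings.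

Open, on these data alone, is whether any group other than these two halogens moves the read-out at this place on the aromatic ring, for instance a methoxy group, a nitrile or an amine. Equally open, as far as these compounds go, is what a carboxylic acid or an amide would do in place of the methyl ester carried by all four compounds.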